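Returning the indazole core with a chlorine added

This account rests on a few compounds, and the source may have more. Where it says the series, first, only, none or still open, it means among the compounds named here.

Measured compounds:
- Compound 1, `CCC/C(=C(/c1ccc(/C=C/C(=O)O)cc1)c1ccc2[nH]ncc2c1)c1ccccc1`: 11 nM
- Compound 2, `O=C(O)/C=C/c1ccc(/C(=C(\c2ccccc2)C2CC2)c2ccc3[nH]ncc3c2)cc1`: 13 nM
- Compound 3, `CC/C(=C(/c1ccc(/C=C/C(=O)O)cc1)c1cc2cn[nH]c2cn1)c1ccccc1`: 442 nM

These numbers come from a functional assay on MCF7 cells (Homo sapiens) for cytotoxicity, read by CellTiter-Glo, with a stated time of 5 days; on this read-out lower numbers stand for stronger inhibition and higher numbers for weaker inhibition. Compound 3 gives the highest number of the three, and its distance from compound 1 and from compound 2 is beyond the scatter, so it is the weakest of the set as measured. Compound 4, `CC/C(=C(/c1ccc(/C=C/C(=O)O)cc1)c1cc(Cl)c2[nH]ncc2c1)c1ccccc1`, has not yet been measured. It differs from compound 3 in one place: a group of 10 heavy atoms (7 carbon, 2 nitrogen, 1 chlorine; one five-membered aromatic ring with 2 hetero atoms, one six-membered aromatic ring of carbon only) in place of a group of 9 heavy atoms (6 carbon, 3 nitrogen; one five-membered aromatic ring with 2 hetero atoms, one six-membered aromatic ring with 1 hetero atom), on a double-bonded chain carbon bound to an aromatic carbon and a double-bonded chain carbon. The entering 7-chloro-1H-indazol-5-yl group matches the corresponding part of compound 1 and compound 2 apart from the added chlorine. For the measured compounds named here, the only measured step, a 1.2-fold higher number from compound 1 to compound 2 (0.07 log units; within the scatter), concerns a different group and was within the scatter, so it gives no guide to this change. What does bear on it is the gap between compound 3 and compounds 1 and 2, which is large and beyond the scatter. Compound 4 is therefore expected to return to a much lower number, with the chlorine an unknown. The expected step is an 18-fold lower number from compound 3 to compound 4 (1.25 log units; beyond the scatter). Compound 4 is estimated at 25 nM, with a range from 8 nM to 100 nM.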

Compound 4, half-maximal inhibitory concentration: 56 nM
Compound 4: middle estimate off by 2.2-fold (0.35 log units), on the low side; measured number inside the range.
By their numbers in this assay, from the lowest: compounds 1 and 2 (each within the scatter of the next); then compound 4; then compound 3.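

In this assay, the change gives a 7.9-fold lower number from compound 3 to compound 4 (0.90 log units; beyond the scatter) and so shows that the number responds strongly to the group at this place, on the double-bonded chain carbon bound to an aromatic carbon. The earlier step between compound 1 and compound 2 lay within the scatter and concerned a different group, so it revealed nothing about this place. No measurement is available here to explain the size of this step.

The step combines two differences, a six-membered aromatic ring of carbon only in place of one with a hetero atom and an added chlorine, and the compounds shown do not separate their contributions. They also leave open how a fluorine, a methyl or a methoxy group would compare with the chlorine in the 7-chloro-1H-indazol-5-yl group.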